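Swapping a Carboxy for a Cyano on a Pyrazole Acid Series

This account rests on a few compounds, and the source may have more. Where it says the series, first, only, none or still open, it means among the compounds named here.

Compound 1 `Cc1n[nH]c(C(=O)O)c1Cc1cccc(C(F)(F)F)c1` and compound 2 `Cc1n[nH]c(C(=O)O)c1Cc1cccc(C(=O)O)c1` share one core and differ only in the group on the outer ring. In an assay on isolated protein for inhibition of 2-Hydroxyacid oxidase 2 (Homo sapiens), tested at 10 uM (on this read-out lower numbers stand for a weaker effect and higher numbers for a stronger effect at the one concentration tested), compound 1 gives 23%, and compound 2 gives 0%. Within the data shown here, compound 2 therefore stands at the bottom of the two numbers known here, and the single step of a number 23 percentage points lower from compound 1 to compound 2 (beyond the scatter) was the only change measured so far.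

Compound 3 `Cc1n[nH]c(C(=O)O)c1Cc1cccc(C#N)c1` is made from compound 2 by the change (cyano in place of carboxy on an aromatic carbon), set on an aromatic carbon of the six-membered ring of carbon only, meta to a large group. Among the measured compounds shown here, no measured step covers cyano directly. For the measured compounds named here, the one step that bears on the outer ring, trifluoromethyl to carboxy, was modest in size and pointed downward, and it shows that this position can move the read-out. Since cyano is neither of those two groups, the expectation is that compound 3 lands somewhere between the two known values, with a step of a number 12 percentage points higher from compound 2 to compound 3 (beyond the scatter) expected upward from compound 2 and of a size near the scatter. The estimate for compound 3 in this assay is 12%, within a range of 0% to 30%.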

Compound 3, a percentage reported as inhibition, at one concentration (the size of the read-out at that concentration, not a potency): 19%
Estimate against measurement, compound 3: 7 percentage points below; low and high end bracket the measured number.
By their numbers in this assay, from the lowest: compound 2; then compounds 3 and 1 (each within the scatter of the next).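

In this assay, the low number of compound 2 does not carry over to every small group on this aromatic carbon: cyano in place of carboxy gives a number 19 percentage points higher from compound 2 to compound 3 (beyond the scatter). Cyano in place of trifluoromethyl gives a number 4 percentage points lower from compound 1 to compound 3 (within the scatter), so this read-out does not separate these two groups, even though they differ in their atoms and heavy-atom makeup. Among the three compounds, carboxy is thus the one group that stands apart at this position, a picture that the single step from compound 1 to compound 2 could not give, and nothing here explains why.

From the compounds shown here alone, whether an amide, an amine or a plain methyl on the same aromatic carbon would fall with compound 1 and compound 3 or with compound 2 remains open, as does the result of an ester, which would show whether carboxy itself must be intact for the low number. Each number also comes from one concentration, so the three compounds can be compared by the size of the effect at that concentration but not by potency.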